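Working notes: methyl to ethyl on the base of compound 2

This account rests on a few compounds, and the source may have more. Where it says the series, first, only, none or still open, it means among the compounds named here.

Of the compounds shown here, two have been measured in a functional assay on MT4 cells (Homo sapiens) for cytotoxicity; on this read-out higher numbers stand for lower toxicity in this test and lower numbers for higher toxicity in this test. Compound 1 `CC(C)(C)[Si](C)(C)OC[C@H]1O[C@@H](n2cnc3cncnc32)[C@H](O[Si](C)(C)C(C)(C)C)[C@]12OS(=O)(=O)C=C2N` gives 13000 nM. Compound 2 `Cn1cnc2ncn([C@@H]3O[C@H](CO[Si](C)(C)C(C)(C)C)[C@@]4(OS(=O)(=O)C=C4N)[C@H]3O[Si](C)(C)C(C)(C)C)c2c1=O` gives 156000 nM, the higher of the two numbers; the step between them is a 12-fold higher number from compound 1 to compound 2 (1.08 log units; beyond the scatter). Among the compounds with values here, that step exchanges the whole base on the saturated ring carbon and is the only measured step so far.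

Compound 3 `CCn1cnc2ncn([C@@H]3O[C@H](CO[Si](C)(C)C(C)(C)C)[C@@]4(OS(=O)(=O)C=C4N)[C@H]3O[Si](C)(C)C(C)(C)C)c2c1=O` differs from compound 2 by methyl in place of hydrogen on a saturated chain carbon bound to an aromatic nitrogen; cut one bond further out, the change reads methyl to ethyl. Within the data shown here, no measured step touches this place: the step from compound 1 to compound 2 concerns a different part of the structure and gives no guidance on the size or direction of a one-carbon growth of the chain on the aromatic nitrogen. With nothing in the data pointing either way, no step beyond the scatter is expected in this assay, and the estimated change from compound 2 to compound 3 is a 1.2-fold lower number from compound 2 to compound 3 (0.08 log units; within the scatter). For compound 3 the expected value is 130000 nM, within 50000 nM to 320000 nM.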

Compound 3, half-maximal cytotoxic concentration: > 150000 nM
Compound 3: a limit, no number (the forecaster's own chance of this, stated with the estimate: 30%); middle value at least 1.1-fold (0.06 log units) from the limit.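

In this assay compound 3 gives > 150000 nM, which is a limit of the assay and not a number. The change of methyl to ethyl on the saturated chain carbon bound to an aromatic nitrogen therefore cannot be sized or given a direction against compound 2, and this step stays unreadable because the only value carrying the ethyl group is a limit: the limit of > 150000 nM in this assay, at which 1 of the 3 values shown sits.

What the result does add is that the large gap to compound 1 first seen with the methyl group also holds with the ethyl group, at an at least 11-fold higher number from compound 1 to compound 3 (1.06 log units; beyond the scatter), a step beyond the scatter. Whether the ethyl group changes the read-out at all relative to the methyl group remains open, since the two compounds shown cannot be ordered on this position. Equally open, going by these compounds, is whether a longer chain such as propyl, or an amine or a carboxylic acid carried on that chain, would give a readable number in this assay and so show what this position tolerates.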